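This account rests on a few compounds, and the source may have more. Where it says the series, first, only, none or still open, it means among the compounds named here.

Measured compounds:
Compound 1, `CCC(C1CC1)n1c(=O)c(C)nc2c(-c3cc(Cl)c(OC)cc3OC)ccnc21`, gives 3.4 nM in a functional assay for antagonist activity at corticotropin-releasing factor receptor 1 (Rattus norvegicus); a higher number here means a weaker inhibitor, a lower number a stronger inhibitor.
Compound 2, `CC[C@H](COC)n1c(=O)c(C)nc2c(-c3ccc(Cl)cc3Cl)ncnc21`, gives 97 nM in this assay.
Compound 3, `CCCC(C)n1c(=O)c(C)nc2c(-c3ccc(Cl)cc3Cl)ccnc21`, gives 62 nM in this assay.

Compound 3 stands second highest of the three numbers. Its nearest neighbour is compound 2, whose number is somewhat higher but within the scatter, so the two cannot be told apart. Its furthest neighbour is compound 1, whose number is lower by a margin well beyond the scatter; compound 1, however, differs from compound 3 in more than one place, so no single change can be read from that gap.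

Compound 4, `CCCC(C1CC1)n1c(=O)c(C)nc2c(-c3ccc(Cl)cc3Cl)ccnc21`, has not yet been measured. It differs from compound 3 in one place: cyclopropyl in place of methyl on a saturated chain carbon bound to an aromatic nitrogen and a saturated chain carbon. Among the compounds with values here, no measured pair shows this change alone. Compound 1 carries the cyclopropyl and gives 3.4 nM, which points toward a lower number, but its other differences leave the size uncertain. A moderate step downward is expected, a 2.5-fold lower number from compound 3 to compound 4 (0.39 log units; beyond the scatter). Compound 4 is estimated at 25 nM, between 8 nM and 80 nM.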

Compound 4, half-maximal inhibitory concentration: 4.3 nM
Compound 4: middle estimate off by 5.8-fold (0.76 log units), on the high side, outside the stated range (below it).
By their numbers in this assay, from the lowest: compounds 1 and 4 (each within the scatter of the next); then compounds 3 and 2 (each within the scatter of the next).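

In this assay, cyclopropyl in place of methyl on a saturated chain carbon bound to an aromatic nitrogen and a saturated chain carbon gives a 14-fold lower number from compound 3 to compound 4 (1.16 log units; beyond the scatter), a large step well beyond the scatter. Within the data shown here, this is the first pair in which the change stands alone, so the 1-methylbutyl to 1-cyclopropylbutyl swap now has a measured size of its own, which compound 1, differing from compound 3 in more than one place, could not supply. Nothing available here accounts for a step of this size.

This single pair leaves open whether the same change would give a similar step on the differently substituted cores of compound 1 and compound 2. It also leaves open how cyclobutyl or an ethyl chain would fare at this same place.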